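Lengthening the chain on compound 1 by one carbon

This account rests on a few compounds, and the source may have more. Where it says the series, first, only, none or still open, it means among the compounds named here.

Measured so far:
compound 1, `CCCCCc1nc(O)cc(O)n1`, 3670 nM
compound 2, `Nc1cc(O)nc(SCCCCc2ccccc2)n1`, > 100000 nM
compound 3, `CCCCCCCCc1cc(O)nc(O)n1`, 811 nM

In a functional assay on HEK293 cells for agonist activity at G-protein coupled receptor 84 (Homo sapiens), read by calcium flux (on this read-out higher numbers stand for an effect only at larger amounts of compound and lower numbers for an effect already at smaller amounts), compound 1 gives 3670 nM, the higher of the two numbers obtained. Compound 3 sits at 811 nM, a lower number than that of compound 1 and beyond the scatter. For compound 2 this assay reports only a limit, (the limit of > 100000 nM in this assay, at which 1 of the 3 values shown sits), and no number. Compound 4, `CCCCCCc1nc(O)cc(O)n1`, is not yet measured. It differs from compound 1 in one place: methyl in place of hydrogen on a saturated chain carbon, five bonds along the chain from an aromatic carbon. The change extends the saturated chain by one carbon. Among the measured compounds, the longer chain of compound 3 goes with a lower number than compound 1, though compound 3 also differs elsewhere, so no single step can be isolated. On that basis compound 4 is expected to give a somewhat lower number than compound 1, a step of a 1.8-fold lower number from compound 1 to compound 4 (0.26 log units; within the scatter), in the direction of stronger effect. The estimate for compound 4 in this assay is 2000 nM, within 800 nM to 5000 nM.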

Compound 4, half-maximal effective concentration: 454 nM
Beside the measured number, compound 4's estimate is 4.4-fold (0.64 log units) above it; measured number outside the range, below it.
By their numbers in this assay, from the lowest: compounds 4 and 3 (each within the scatter of the next); then compound 1. At a limit, above all of these: compound 2.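

In this assay, methyl in place of hydrogen on a saturated chain carbon, five bonds along the chain from an aromatic carbon, brings an 8.1-fold lower number from compound 1 to compound 4 (0.91 log units; beyond the scatter). Within the data shown here, with everything else in the structure unchanged, this is the first reading of a single change at this position, and it shows that one added carbon on the chain is enough on its own to move the number beyond the scatter, which no earlier pair could show. Nothing at hand bears on why the added carbon has an effect of this size.

On these data alone, it remains open whether a longer chain on the core of compound 4 would lower the number further or reverse the step. As far as these compounds go, how a branched chain, or an amine or a carboxylic acid at the end of the chain, would read at this position is equally open.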